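A few compounds are considered here, and "the series" means these few. Any claim that something is new, unique, unknown or untested is made for them only; others in the source may bear on it.

Compound 1 `O=c1c(SC(=S)N2CCCCC2)coc2ccccc12` and compound 3 `O=c1c(SC(=S)N2CCCCC2)coc2ccc(Cl)cc12` share one core, while compound 2 `CC(C)N(C(=S)SCc1cc(=O)c2ccc(Cl)cc2o1)C(C)C` and compound 4 `CC(C)N(C(=S)SCc1cc(=O)c2ccccc2o1)C(C)C` share another; the difference between the two cores is not broken down here. In a functional assay on LM7 cells (Homo sapiens) for antiproliferative activity, read by MTT assay, with a stated time of 72 h (on this read-out lower numbers stand for stronger inhibition and higher numbers for weaker inhibition), compound 1 gives 7800 nM. In this assay compound 3 reaches only the limit > 25000 nM. The change from compound 3 to compound 1 is hydrogen in place of chloro on an aromatic carbon, and it brings an at least 3.2-fold lower number from compound 3 to compound 1 (0.50 log units; beyond the scatter). In this assay compound 2 likewise reaches only the limit > 30000 nM. The same change, (hydrogen in place of chloro on an aromatic carbon), turns compound 2 into compound 4. Resting on the measured at least 3.2-fold lower number from compound 3 to compound 1 (0.50 log units; beyond the scatter), a step of an at least 2.5-fold lower number from compound 2 to compound 4 (0.39 log units; beyond the scatter) is expected in this assay, with the caution that compound 2 sits at a limit. Compound 4 is therefore estimated at 12000 nM, most likely between 4000 nM and 40000 nM.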

Compound 4, half-maximal inhibitory concentration: > 25000 nM
Compound 4 was reported as a limit; the forecaster's own chance of this, stated with the estimate: 35%; at least 2.0-fold (0.31 log units) between middle value and limit.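

Compound 2 and compound 4 both stand at limits in this assay, and the step between them cannot be read. The compounds shown leave open whether hydrogen in place of chloro changes the number at all on the core these two share.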